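Fluoro in Place of Chloro: From Compound 2 to Compound 3

The compounds below may be only part of what the source reports. "The series", "measured", "known", "first", "only" and "open" are said of these compounds alone.

Compound 1 `COc1cc(O)c(C(=O)/C=C/c2ccc(F)cc2)c(OC)c1` and compound 2 `COc1cc(OC)c(C(=O)/C=C/c2ccc(Cl)cc2)c(OC)c1` have both been tested in a functional assay on Caco-2 cells (Homo sapiens) for cytotoxicity, with a stated time of 48 h; a higher number here means a weaker inhibitor, a lower number a stronger inhibitor. In this assay compound 1 gives 9200 nM, and compound 2 gives 5700 nM. Compound 2 has the lowest of the two numbers, but its gap to compound 1 lies within the scatter, so neither compound can be called the stronger inhibitor. Compound 3 `COc1cc(OC)c(C(=O)/C=C/c2ccc(F)cc2)c(OC)c1` has not yet been measured. It differs from compound 2 by fluoro in place of chloro on an aromatic carbon. Within the data shown here, no step between measured compounds that differ in one place is available, and the single comparison at hand, between compound 1 and compound 2, involves more than this one change. The step is therefore expected to be small, a 1.4-fold higher number from compound 2 to compound 3 (0.15 log units; within the scatter), in either direction or none beyond the scatter. Compound 3 is estimated at 8000 nM, with a range from 4000 nM to 16000 nM.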

Compound 3, half-maximal inhibitory concentration: 5500 nM
Compound 3: middle estimate off by 1.5-fold (0.16 log units), on the high side, within the range that was stated.
By their numbers in this assay, from the lowest: compounds 3, 2 and 1 (each within the scatter of the next).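

In this assay, among these compounds, 4-chlorophenyl to 4-fluorophenyl, on an aromatic carbon para to a large group, gives a 1.0-fold lower number from compound 2 to compound 3 (0.02 log units; within the scatter) and is the first reading of this change on its own: at this position, the two halogens cannot be told apart. The second single change, methyl in place of hydrogen on an oxygen on an aromatic ring, gives a 1.7-fold lower number from compound 1 to compound 3 (0.22 log units; within the scatter) and likewise leaves the two compounds indistinguishable, which resolves the earlier comparison of compound 1 and compound 2 into two steps, each within the scatter. No evidence at hand bears on either result.

The compounds shown leave open whether an amine or a carboxylic acid in place of the halogen would move the number beyond the scatter. They also leave open whether a longer chain in place of the methyl on that oxygen would do so.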